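Adding aminomethyl to the anilide of compound 3

The compounds below may be only part of what the source reports. "The series", "measured", "known", "first", "only" and "open" are said of these compounds alone.

Three measured compounds open the account. Compound 1 `NCc1csc(NC(=O)c2ccc(Cl)cc2)n1` gives 25 ug/mL in a physicochemical assay for solubility, read by nephelometry, measured as kinetic solubility, at pH 6.5; a lower number here means a less soluble compound, a higher number a more soluble compound. Compound 2 `NCc1csc(NC(=O)c2ncccn2)n1` is reported in this assay only as a limit, > 100 ug/mL, and not as a number (the limit of > 100 ug/mL in this assay, at which 1 of the 3 values shown sits). Compound 3 `CC(C)(C)c1cc(C(=O)Nc2ccccc2)n(Cc2ccccc2)n1` gives 1.6 ug/mL in this assay, the lowest of the two numbers shown, with compound 1 standing higher by a gap beyond the scatter.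

The unmeasured compound is compound 4 `CC(C)(C)c1cc(C(=O)Nc2cccc(CN)c2)n(Cc2ccccc2)n1`. It differs from compound 3 in one place: aminomethyl in place of hydrogen on an aromatic carbon. For the measured compounds named here, no measured pair among the three compounds shows this same change, so the step has no direct precedent here; compound 1 carries an aminomethyl on a different core, and its value says nothing about the step itself.

The step from compound 3 to compound 4 is expected to raise solubility clearly beyond the scatter, by about a 13-fold higher number from compound 3 to compound 4 (1.10 log units; beyond the scatter). For compound 4 the expected solubility in this assay is 20 ug/mL, with a range from 5 ug/mL to 80 ug/mL.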

Compound 4, solubility: 25 ug/mL
For compound 4 the middle estimate is 1.3-fold (0.10 log units) below the measured one; low and high end bracket the measured number.
By their numbers in this assay, from the lowest: compound 3; then compounds 1 and 4 (each within the scatter of the next). At a limit, above all of these: compound 2.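

In this assay, for the compounds shown here, the only measured pair that differs in one place gives a 16-fold higher number from compound 3 to compound 4 (1.19 log units; beyond the scatter), a large step for aminomethyl in place of hydrogen on an aromatic carbon. Going by these compounds alone, this is the first reading of that change in the set, and it shows that at this position, on a six-membered aromatic ring of carbon only and meta to a large group, the change moves the number well beyond the scatter. The compounds shown give no measured reason for a step of this size.

Going by these compounds, it remains open whether aminomethyl would give a similar step at another place on that ring or on another core. On these data alone, it is equally open whether a longer chain such as aminoethyl, a tertiary amine or a carboxylic acid at this position would move the number in the same direction.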